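This account rests on a few compounds, and the source may have more. Where it says the series, first, only, none or still open, it means among the compounds named here.

Compound 1 `COc1ccc(-c2cc(/C=C/C(=O)c3ccc(N)cc3)[nH]n2)cc1` and compound 2 `COc1cc(-c2cc(/C=C/C(=O)c3ccc(N)cc3)[nH]n2)cc(OC)c1OC` share the same core and differ only in how many methoxy groups sit on one six-membered aromatic ring of carbon only. In a functional assay on OVCAR-8 cells (Homo sapiens) for cytotoxicity, read by sulforhodamine B assay, with a stated time of 48 h, tested at 10 uM (a lower number here means a stronger effect, a higher number a weaker effect of the compound at the concentration tested), compound 1 gives 9%. In this assay, among the compounds with values here, compound 2 gives -1%, one of only two numbers in hand, and the gap to compound 1 lies within the usual scatter, so the two cannot be told apart. Compound 3 `COc1ccc(-c2cc(/C=C/C(=O)c3ccc(N)cc3)[nH]n2)cc1OC` has not yet been measured; it arises from compound 2 by hydrogen in place of methoxy on an aromatic carbon. The numbers for compound 1 and compound 2 sit within the scatter of each other although the two compounds differ by two methoxy groups, so a change of one methoxy fewer is expected to move the read-out no further: the expected step is a number 5 percentage points higher from compound 2 to compound 3 (within the scatter), nothing beyond the scatter. Compound 3 is therefore estimated to give about 4% in this assay, most likely between -12% and 20%.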

Compound 3, a percentage reported as activity, at one concentration (the size of the read-out at that concentration, not a potency): 2%
Compound 3: middle estimate off by 2 percentage points, on the high side, within the range that was stated.
By their numbers in this assay, from the lowest: compounds 2, 3 and 1 (each within the scatter of the next).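

Hydrogen in place of methoxy on this aromatic carbon, ortho to a methoxy group and meta to a large group, gives a number 3 percentage points higher from compound 2 to compound 3 (within the scatter) in this assay, and methoxy in place of hydrogen gives a number 7 percentage points lower from compound 1 to compound 3 (within the scatter) on the other side of the series. Within the data shown here, each single change can now be read on its own, which the two-methoxy gap between the earlier compounds did not allow, and neither step can be told from repeat scatter. Nothing at hand explains why this position tolerates either group.

As far as these compounds go, whether a hydroxyl group, an ethoxy chain or a carboxylic acid at this carbon would move the read-out beyond the scatter stays open. So does whether these three compounds would separate at a lower concentration, where a single reading might show differences hidden here.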